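The compounds below may be only part of what the source reports. "The series", "measured", "known", "first", "only" and "open" are said of these compounds alone.

Measured so far in an ADME assay on cells (Hepatocyte, Rattus norvegicus) for metabolic stability, using equilibrium dialysis; on this read-out higher numbers stand for fast clearance and lower numbers for slow clearance:

Compound 1 `CC(=O)N[C@@H]1CCC[C@H](C(=O)Nc2cc(-c3cnn4c3CCCC4)c(F)cn2)C1`: 73 uL/min
Compound 2 `CC(=O)N[C@@H]1CCC[C@H](C(=O)Nc2cc(-c3cnn4c3CC(C)(C)CC4)ccn2)C1`: 35 uL/min
Compound 3 `CC(=O)N[C@@H]1CCC[C@H](C(=O)Nc2cc(-c3cnn4c3CC(C)(C)C4)ccn2)C1`: 45 uL/min

Among these three numbers compound 3 stands second highest. Its nearest neighbour is compound 2, and the gap between them lies within the usual scatter of this assay, so the two cannot be told apart. The gap to compound 1, which has the highest number, is also within the scatter. The three compounds share the same core and differ only in the saturated ring fused to it and in whether a fluorine sits on the pyridine ring.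

Compound 4 `CC(=O)N[C@@H]1CCC[C@H](C(=O)Nc2cc(-c3cnn4c3CC(C)(C)C4)c(F)cn2)C1` is not yet measured. It differs from compound 3 in one place: fluoro in place of hydrogen on an aromatic carbon.

No measured pair differs by this change alone, so there is no shown step to lean on. Compound 1 carries the same fluorine and sits highest, but it also carries a different saturated ring, so its value alone cannot be assigned to the fluorine. A small step upward, not clearly beyond the scatter, is expected from compound 3 to compound 4, namely a 1.2-fold higher number from compound 3 to compound 4 (0.09 log units; within the scatter). For compound 4 the estimated value is 55 uL/min, with a range from 28 uL/min to 110 uL/min.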

Compound 4, intrinsic clearance in a liver preparation (reported as CLH), per the amount of preparation that the assay uses in the Hepatocyte assay: 81 uL/min
Compound 4: middle estimate off by 1.5-fold (0.17 log units), on the low side; measured number inside the range.
By their numbers in the Hepatocyte assay, from the lowest: compounds 2, 3, 1 and 4 (each within the scatter of the next, the first and the last beyond it).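

In the Hepatocyte assay, fluoro in place of hydrogen on this aromatic carbon gives a 1.8-fold higher number from compound 3 to compound 4 (0.26 log units; within the scatter), while changing the saturated ring with the fluorine kept in place gives a 1.1-fold higher number from compound 1 to compound 4 (0.05 log units; within the scatter), so neither change can be told apart from repeat-to-repeat variation. In a physicochemical assay for lipophilicity, using the shake flask method, measured as octanol-water partition, at pH 7.4 (on this read-out higher numbers stand for higher lipophilicity and lower numbers for lower lipophilicity), compound 3 gives 2.8 and compound 4 gives 3.3. The fluorine therefore produces a clear rise in measured lipophilicity, even though no clear shift in clearance can be claimed: the measured distribution coefficient of compound 3, 2.8, and of compound 4, 3.3, a number 0.50 log units higher (beyond the scatter)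

A single pair cannot show whether clearance and lipophilicity move together at this position. As far as these compounds go, it also remains open how a different group on this aromatic carbon, such as chloro, methoxy, nitrile or an amine, would affect either read-out.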